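Sulfone side chain trimmed on the shared core

A few compounds are considered here, and "the series" means these few. Any claim that something is new, unique, unknown or untested is made for them only; others in the source may bear on it.

Three analogues carry a methylsulfonyl-bearing substituent on the shared core. In a physicochemical assay for solubility, in phosphate buffer, measured as kinetic solubility, with a stated time of 1 h, at pH 7.4 (on this read-out lower numbers stand for lower solubility and higher numbers for higher solubility), compound 1 `CNCC(=O)Nc1ccc(-c2nc(CS(C)(=O)=O)cc([C@]34CCOC[C@H]3C4)n2)cc1` gives 158 ug/mL, compound 2 `CC(C)(c1cc([C@]23CCOC[C@H]2C3)nc(-c2ccc(NC(=S)NCCO)cc2)n1)S(C)(=O)=O` gives 173 ug/mL, and compound 3 `CNCC(=O)Nc1ccc(-c2nc(C(C)(C)S(C)(=O)=O)cc([C@@]34CCOC[C@@H]3C4)n2)cc1` gives 257 ug/mL. Compound 3 holds the highest of the three numbers, yet its gaps to compound 2 and to compound 1 both fall within the scatter, so the three read as one level. Compound 4 `CNCC(=O)Nc1ccc(-c2nc(CS(C)(=O)=O)cc([C@@]34CCOC[C@@H]3C4)n2)cc1` is not yet measured in this assay; it differs from compound 3 by (methylsulfonyl)methyl in place of 1-methyl-1-(methylsulfonyl)ethyl on an aromatic carbon. Within the data shown here, no measured pair isolates this change, so the step of a 1.4-fold lower number from compound 3 to compound 4 (0.15 log units; within the scatter) is expected to stay within the scatter, leaning slightly downward. For compound 4 a value of 180 ug/mL is estimated, between 100 ug/mL and 320 ug/mL.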

Compound 4, solubility: 167 ug/mL
Estimate against measurement, compound 4: 1.1-fold (0.03 log units) above; the measured number falls inside the stated range.
By their numbers in this assay, from the lowest: compounds 1, 4, 2 and 3 (each within the scatter of the next).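

In this assay, among these compounds, the first pair to isolate this change, (methylsulfonyl)methyl in place of 1-methyl-1-(methylsulfonyl)ethyl, gives a 1.5-fold lower number from compound 3 to compound 4 (0.19 log units; within the scatter), so the two substituents read as one level at this position. The mirror-image pair gives a 1.1-fold higher number from compound 1 to compound 4 (0.02 log units; within the scatter), which also reads as one level and shows no separation by configuration on the read-out, the comparison being clean on this ground: the fact that compounds 1 and 4 differ only in the configuration as drawn

Still open, as far as these compounds go, is whether an amine or a carboxylic acid on this aromatic carbon would leave that level. From the compounds shown here alone, a longer chain carrying the sulfone is equally open.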